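This account rests on a few compounds, and the source may have more. Where it says the series, first, only, none or still open, it means among the compounds named here.

Going by the values given here, in a functional assay on HCT-116 cells (Homo sapiens) for antiproliferative activity, read by CCK-8 assay, with a stated time of 72 h (on this read-out lower numbers stand for stronger inhibition and higher numbers for weaker inhibition), three compounds built on a shared core have numbers so far. Compound 1 (`Cc1ccc(Nc2nc(Cl)nc3c2ncn3Cc2ccc(C(=O)Nc3ccccc3N)cc2)cc1`) gives 580 nM, compound 2 (`Nc1ccccc1NC(=O)c1ccc(Cn2cnc3c(NCc4ccccc4)nc(Cl)nc32)cc1`) gives 1060 nM, and compound 3 (`Nc1ccccc1NC(=O)c1ccc(Cn2cnc3c(Nc4ccc(-c5ccccn5)cc4)nc(Cl)nc32)cc1`) gives 1250 nM. Compound 3 stands within the scatter of compound 2, with a 1.2-fold higher number from compound 2 to compound 3 (0.07 log units; within the scatter), but the data also show a 2.2-fold higher number from compound 1 to compound 3 (0.33 log units; beyond the scatter).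

Compound 4 (`Nc1ccccc1NC(=O)c1ccc(Cn2cnc3c(Nc4cccc(Cl)c4)nc(Cl)nc32)cc1`) changes compound 3 at a single place: 3-chlorophenyl in place of 4-(pyridin-2-yl)phenyl on a nitrogen on an aromatic ring. The closest measured comparison is compound 1, which carries 4-methylphenyl on the same nitrogen, and its step to compound 3 is the only one beyond the scatter. The remaining step, a 1.8-fold higher number from compound 1 to compound 2 (0.26 log units; within the scatter), stays within the scatter, so the series responds only mildly to changes at this nitrogen. Among the compounds with values here, no measured compound carries 3-chlorophenyl, so the data do not test that group directly.

A small move toward the value of compound 1 therefore seems likeliest. The expected change is a 1.8-fold lower number from compound 3 to compound 4 (0.25 log units; within the scatter), which may not clear the scatter. Compound 4 is estimated at 700 nM, with an expected range of 300 nM to 1500 nM.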

Compound 4, half-maximal inhibitory concentration: 2340 nM
The estimate for compound 4 lay 3.3-fold (0.52 log units) below the measured number; measured number above the stated range.
By their numbers in this assay, from the lowest: compounds 1, 2, 3 and 4 (each within the scatter of the next, the first and the last beyond it).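

In this assay, going by these compounds alone, 3-chlorophenyl in place of 4-methylphenyl on this nitrogen gives the largest step seen at this position (a 4.0-fold higher number from compound 1 to compound 4 (0.61 log units; beyond the scatter)), and the step from benzyl also lies beyond the scatter (a 2.2-fold higher number from compound 2 to compound 4 (0.34 log units; beyond the scatter)), so the position responds more than the earlier compounds showed. Replacing the 12 heavy atoms of 4-(pyridin-2-yl)phenyl with the 7 of 3-chlorophenyl brought no gain toward compound 1, as the step stays within the scatter (a 1.9-fold higher number from compound 3 to compound 4 (0.27 log units; within the scatter)). No evidence is available that accounts for this result.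

What a 4-chlorophenyl or a 3-methylphenyl group on this nitrogen would give stays open, so the compounds shown cannot separate the effect of the chlorine from that of its place on the ring.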